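Swapping One Hydroxyphenyl for Another Before Compound 3 Is Tested

The source may report more compounds than this note shows. Statements on the series, on what has been measured and on what is new or still open speak of the compounds shown alone.

Compound 1 `Oc1ccc(-c2cc(-c3ccc(C(F)(F)F)cc3)cc(-c3ccccc3O)n2)cc1` and compound 2 `Oc1cccc(-c2cc(-c3ccc(C(F)(F)F)cc3)cc(-c3cccc(O)c3)n2)c1` share a core and each carry two hydroxyphenyl groups. In a functional assay on HCT-15 cells (Homo sapiens) for inhibition (a lower number here means a stronger inhibitor, a higher number a weaker inhibitor), compound 1 reaches only the assay limit, > 50000 nM. In this assay compound 2 likewise gives only a limit, > 50000 nM. Compound 2 thus stands where every value shown stands, at the limit (the limit of > 50000 nM in this assay, at which 2 of the 2 values shown sit). Compound 3 `Oc1ccc(-c2cc(-c3ccc(C(F)(F)F)cc3)cc(-c3cccc(O)c3)n2)cc1` takes a single change from compound 2: 4-hydroxyphenyl in place of 3-hydroxyphenyl on an aromatic carbon. With both measured compounds at the limit, the expected step is a step that the limit leaves unreadable from compound 2 to compound 3, nothing beyond the usual scatter. Compound 3 is estimated at 80000 nM, within a range from 30000 nM to 300000 nM, and most likely again reported only as a limit.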

Compound 3, half-maximal inhibitory concentration: 6440 nM
Compound 3: the middle estimate sits 12-fold (1.09 log units) above what was measured, outside the stated range (below it).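

With the same atoms, 4-hydroxyphenyl in place of 3-hydroxyphenyl gives an at least 7.7-fold lower number from compound 2 to compound 3 (0.89 log units; beyond the scatter) in this assay and so shows that this position responds to the choice of isomer. At the other hydroxyphenyl group, 3-hydroxyphenyl in place of 2-hydroxyphenyl gives an at least 7.7-fold lower number from compound 1 to compound 3 (0.89 log units; beyond the scatter) and so compound 3 alone of the three comes in under the limit. Both steps are only minimum sizes because compound 1 and compound 2 carry no exact number: the limit of > 50000 nM in this assay, at which 2 of the 3 values shown sit.

On these data alone, the true size of each step stays open. So does the effect of 4-hydroxyphenyl at both places, or of an amine or a carboxylic acid in place of the hydroxyl.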